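A few compounds are considered here, and "the series" means these few. Any claim that something is new, unique, unknown or untested is made for them only; others in the source may bear on it.

Compound 2 `COc1cc(C(=O)N2CCCC2)ccc1-c1ccnc2[nH]c(C3CCOCC3)cc12` gives the lowest number of the three in an ADME assay (Rattus norvegicus, strain Han-wistar) for pharmacokinetics, at a dose of 1.5 umol/kg by the intravenous route (on this read-out higher numbers stand for wider distribution into tissues and lower numbers for narrower distribution), namely 0.8 L/kg. Compound 4 `COc1cc(C(=O)N2CCCC2)ccc1-c1ccnc2[nH]c(C3CCNCC3)cc12` differs from it in one place: piperidin-4-yl in place of oxan-4-yl on an aromatic carbon. Among the measured compounds shown here, no measured step follows this exact change; the only recorded one, a 2.0-fold higher number from compound 1 to compound 3 (0.31 log units; beyond the scatter), concerns a different part of the molecule. Still, compound 1 `CC(C)n1nc(-c2ccnc3[nH]c(C4CCN(CC(=O)N(C)C)CC4)cc23)ccc1=O`, which carries a piperidin-4-yl group at the same place, gives 2.9 L/kg, and compound 3 `CC(C)n1cc(-c2ccnc3[nH]c(C4CCN(CC(=O)N(C)C)CC4)cc23)ccc1=O` gives 5.9 L/kg, both beyond the scatter above compound 2, although they also differ from it elsewhere. On that basis compound 4 is expected to show an upward step, a 3.1-fold higher number from compound 2 to compound 4 (0.49 log units; beyond the scatter). The estimate for compound 4 is 2.5 L/kg, with a range from 1 L/kg to 6 L/kg.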

Compound 4, volume of distribution: 5.8 L/kg
Beside the measured number, compound 4's estimate is 2.3-fold (0.37 log units) below it; the range from low to high includes it.
By their numbers in this assay, from the lowest: compound 2; then compounds 1, 4 and 3 (each within the scatter of the next, the first and the last beyond it).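

With the rest of the molecule unchanged, piperidin-4-yl in place of oxan-4-yl gives a 7.3-fold higher number from compound 2 to compound 4 (0.86 log units; beyond the scatter) in this assay. The earlier compounds shown here could not show this, as those carrying a piperidine ring at this place also differ from compound 2 elsewhere. Here the exchange is confined to the ring hetero atom of the group on the aromatic carbon next to the ring nitrogen, and that alone moves the read-out beyond the scatter.

On these data alone, whether a cyclohexyl ring at this place would read nearer compound 2 or compound 4 stays open. No measurement shown bears on this step.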